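Trimming the ring-nitrogen substituent from ethyl to methyl

The source may report more compounds than this note shows. Statements on the series, on what has been measured and on what is new or still open speak of the compounds shown alone.

Compound 1 `CN1CCN(CCCNC(=O)n2c(=O)n(C3CC3)c3ccccc32)CC1`: 0.46
Compound 2 `CCn1c(=O)n(C(=O)NCCN2CCN(C)CC2)c2ccccc21`: < 0.3

Two compounds sharing a core and a piperazine-bearing side chain have been tested in a functional assay for agonist activity at 5-hydroxytryptamine receptor 4 (Cavia porcellus); on this read-out higher numbers stand for larger maximal responses and lower numbers for smaller maximal responses. Compound 1 gives 0.46. Compound 2 reaches only the limit of the assay, < 0.3, so no number is known for it; it sits at the limit of < 0.3 in this assay, at which 1 of the 2 values shown sits. Compound 3 `CN1CCN(CCNC(=O)n2c(=O)n(C)c3ccccc32)CC1` is not yet measured. Its difference from compound 2 is hydrogen in place of methyl on a saturated chain carbon bound to an aromatic nitrogen.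

Within the data shown here, no measured pair differs in one place only, so the size of this step has no direct precedent. Since compound 2 sits at the limit, the step from compound 2 to compound 3 is expected to be small, likely within the usual scatter, and compound 3 is estimated at 0.3 with a range from 0.15 to 0.5, which also means a number no lower from compound 2 to compound 3 (the limit leaves the size open).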

Compound 3, intrinsic activity: the largest response reached, as a fraction of the reference agonist's: 0.42
Compound 3: the middle estimate sits 0.12 below what was measured, within the range that was stated.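

In this assay, hydrogen in place of methyl on a saturated chain carbon bound to an aromatic nitrogen gives a number at least 0.12 higher from compound 2 to compound 3 (beyond the scatter). Among these compounds, this is the first reading of this position on its own: with the piperazine-bearing side chain held the same, the change from ethyl to methyl alone moves the maximal response. The value of compound 2 is a limit and not a number, so the step fixes only a lower bound on the size of the change: the limit of < 0.3 in this assay, at which 1 of the 3 values shown sits.

Compound 1 carries cyclopropyl at this position but also differs in the side chain, so it cannot show how cyclopropyl alone compares with methyl or ethyl. On these data alone, whether a smaller or a branched group here, such as a bare hydrogen or isopropyl, would keep the response remains open.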